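Adding a Second Methoxy Group to Compound 3

This account rests on a few compounds, and the source may have more. Where it says the series, first, only, none or still open, it means among the compounds named here.

Of the compounds shown here, three have been measured in an assay on isolated protein for inhibition of Aromatase (Homo sapiens), with stated times of 1 min and 60 min, tested at 1 uM; on this read-out lower numbers stand for less inhibition and higher numbers for more inhibition at the one concentration tested (going by the name of the read-out). Compound 1 `O=C(Nc1ccccc1)OC(COc1ccccc1)Cn1ccnc1` gives 27%, compound 2 `O=C(Nc1ccc(Cl)cc1)OC(COc1ccccc1)Cn1ccnc1` gives 72%, and compound 3 `COc1ccc(NC(=O)OC(COc2ccccc2)Cn2ccnc2)cc1` gives 61%. Compound 3 thus stands second highest of the three: the step of a number 11 percentage points lower from compound 2 to compound 3 (beyond the scatter) separates it from compound 2, while a number 34 percentage points higher from compound 1 to compound 3 (beyond the scatter) separates it from compound 1. Compound 4 `COc1ccc(NC(=O)OC(COc2ccccc2)Cn2ccnc2)c(OC)c1` differs from compound 3 by methoxy in place of hydrogen on an aromatic carbon. The step that bears most directly on this change is the earlier replacement of hydrogen by methoxy, a number 34 percentage points higher from compound 1 to compound 3 (beyond the scatter), a large rise; a number 45 percentage points higher from compound 1 to compound 2 (beyond the scatter) was large as well. A second methoxy, here ortho to a large group, need not repeat that gain, so only a small rise is expected: a number 5 percentage points higher from compound 3 to compound 4 (within the scatter). Compound 4 is therefore estimated to give 66%, within 45% to 85%.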

Compound 4, a percentage reported as inhibition, at one concentration (the size of the read-out at that concentration, not a potency): 25%
Estimate against measurement, compound 4: 41 percentage points above; measured number outside the range, below it.
By their numbers in this assay, from the lowest: compounds 4 and 1 (each within the scatter of the next); then compound 3; then compound 2.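

In this assay, methoxy in place of hydrogen on an aromatic carbon does not act in one direction: the change gave a number 34 percentage points higher from compound 1 to compound 3 (beyond the scatter), whereas here it gave a number 36 percentage points lower from compound 3 to compound 4 (beyond the scatter). The outcome of this replacement therefore depends on its place or on the methoxy already present, and this carbon, ortho to a large group and meta to a methoxy group, is one where it lowers the number. Nothing available explains this drop. The compounds shown leave open whether fluoro or methyl on this same carbon would also lower the number. They also leave open whether methoxy here would have the same effect with chloro in place of the existing methoxy group.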